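A few compounds are considered here, and "the series" means these few. Any claim that something is new, unique, unknown or untested is made for them only; others in the source may bear on it.

Working notes on the series.

In an assay on isolated protein for inhibition of histamine H2 receptor (Cavia porcellus) (on this read-out higher numbers stand for weaker binding and lower numbers for tighter binding), compound 3 `CNC(=O)NCCCOc1cccc(CN2CCCCC2)c1` gives 155 nM and compound 1 `CC(C)CNC(=O)NCCCOc1cccc(CN2CCCCC2)c1` gives 170 nM; these two are within the scatter of each other, so no order can be read between them. Compound 2 `Cc1ccc(NC(=O)NCCCOc2cccc(CN3CCCCC3)c2)cc1` gives 631 nM in this assay, and the steps of a 4.1-fold lower number from compound 2 to compound 3 (0.61 log units; beyond the scatter) and a 3.7-fold higher number from compound 1 to compound 2 (0.57 log units; beyond the scatter) both lie beyond the scatter, so compound 2 stands apart from the other two, while the step of a 1.1-fold lower number from compound 1 to compound 3 (0.04 log units; within the scatter) does not.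

Compound 4 `CCC(C)NC(=O)NCCCOc1cccc(CN2CCCCC2)c1` has not yet been measured in this assay. It differs from compound 3 by sec-butyl in place of methyl on an amide-type nitrogen. Within the data shown here, the step that bears most directly on this is the one from compound 1 to compound 3, where isobutyl was cut back to methyl on the same nitrogen, and it read a 1.1-fold lower number from compound 1 to compound 3 (0.04 log units; within the scatter). Among the measured compounds shown here, the only step beyond the scatter on this nitrogen, a 4.1-fold lower number from compound 2 to compound 3 (0.61 log units; beyond the scatter), concerns an aryl group and does not speak to a branched alkyl. On that basis an alkyl of this size on the amide-type nitrogen is expected to leave the number about where it is: the estimated step is a 1.0-fold higher number from compound 3 to compound 4 (0.01 log units; within the scatter), not beyond the scatter. Compound 4 is therefore expected to give about 160 nM in this assay, with a range from 80 nM to 320 nM.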

Compound 4, dissociation constant: 95.5 nM
Estimate against measurement, compound 4: 1.7-fold (0.22 log units) above; low and high end bracket the measured number.
By their numbers in this assay, from the lowest: compounds 4, 3 and 1 (each within the scatter of the next); then compound 2.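

With sec-butyl on the amide-type nitrogen, the alkyl groups in this assay now span a wider range of sizes, from the single carbon of methyl to the four carbons of sec-butyl, and still show no order: a 1.6-fold lower number from compound 3 to compound 4 (0.21 log units; within the scatter) and a 1.8-fold lower number from compound 1 to compound 4 (0.25 log units; within the scatter) both stay within the scatter. Moving the branch from isobutyl to sec-butyl therefore cannot be read as a change at this position, and the three alkyl compounds 1, 3 and 4 form one group on this read-out. The separation of 4-methylphenyl from that group now rests on a third alkyl partner, with a 6.6-fold lower number from compound 2 to compound 4 (0.82 log units; beyond the scatter) beyond the scatter, and no measured evidence explains why the aryl compound stands apart or why the alkyl compounds read alike.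

From the compounds shown here alone, it remains open whether the level reading extends to a longer chain such as n-octyl, to a cyclohexyl ring, or to an alkyl chain carrying a hydroxyl, an amine or a carboxylic acid. Also open, going by these compounds, is whether the gap belongs to 4-methylphenyl alone or also holds for unsubstituted phenyl or benzyl on this nitrogen.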